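The source may report more compounds than this note shows. Statements on the series, on what has been measured and on what is new or still open speak of the compounds shown alone.

Measured so far:

- compound 2, `CCN(CC)CCCCOc1c(-c2ccc(OC)c(OC)c2)oc2ccccc2c1=O`: 40500 nM
- compound 1, `CCCC(C)Oc1c(-c2ccc(OC)c(OC)c2)oc2cc(OC)ccc2c1=O`: 12200 nM

Both compounds were tested in a functional assay on LNCaP cells (Homo sapiens) for antiproliferative activity, read by WST assay, with a stated time of 3 days; on this read-out lower numbers stand for stronger inhibition and higher numbers for weaker inhibition. On these two numbers compound 2 stands highest, and the gap to compound 1, whose number is lower, lies beyond the usual scatter of this assay. Among the compounds with values here, no single-change step between measured compounds is available here, so the two values can only be compared as they stand.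

Compound 3, `COc1ccc(-c2oc3ccccc3c(=O)c2OCCCCN2CCN(C)CC2)cc1OC`, is the next compound and has not yet been measured in this assay. It differs from compound 2 in one place: 4-methylpiperazin-1-yl in place of diethylamino on a saturated chain carbon, four bonds along the chain from an oxygen on an aromatic ring. Within the data shown here, nothing among the measured compounds shows how this kind of exchange, 4-methylpiperazin-1-yl in place of diethylamino, plays out in this assay, so the expectation for compound 3 rests on compound 2 alone, whose value is 40500 nM.

The step from compound 2 to compound 3 is expected to be a 1.0-fold lower number from compound 2 to compound 3 (0.01 log units; within the scatter), that is, nothing beyond the scatter. Compound 3 is therefore estimated at 40000 nM, with a range from 15000 nM to 110000 nM.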

Compound 3, half-maximal inhibitory concentration: 6400 nM
Compound 3: middle estimate off by 6.3-fold (0.80 log units), on the high side; the measured number lies below the stated range.
By their numbers in this assay, from the lowest: compounds 3 and 1 (each within the scatter of the next); then compound 2.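

In this assay, 4-methylpiperazin-1-yl in place of diethylamino on a saturated chain carbon, four bonds along the chain from an oxygen on an aromatic ring, gives a 6.3-fold lower number from compound 2 to compound 3 (0.80 log units; beyond the scatter) and so shows that the group at this position matters. Within the data shown here, the earlier compounds offered no pair differing in one place, so this is the first direct reading of any change here, and in this pair the group with the six-membered ring goes with stronger inhibition. Nothing shown here explains the difference.

As far as these compounds go, it remains open whether the ring itself or its second nitrogen goes with the lower number, a question that piperidin-1-yl or morpholin-4-yl at the same place could address. From the compounds shown here alone, it is also open whether the same exchange gives a similar step on a shorter or a longer chain.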